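Chloro for trifluoromethyl on the urea aryl of compound 2

This account rests on a few compounds, and the source may have more. Where it says the series, first, only, none or still open, it means among the compounds named here.

Two members of this series have a number in a functional assay on MDA-MB-231 cells (Homo sapiens) for inhibition, read by sulforhodamine B assay, with a stated time of 48 h, tested at 0.01 uM (on this read-out lower numbers stand for a stronger effect and higher numbers for a weaker effect at the one concentration tested), so far. Compound 1 `O=C(Nc1cccc(-n2cc(-c3ccncc3)c(-c3cc(O)cc(Cl)c3)n2)c1)Nc1ccc(Cl)c(Cl)c1` carries a hydroxy group on its chlorophenyl arm and a dichlorophenyl urea; in this assay compound 1 gives 94%. Compound 2 `COc1cc(Cl)cc(-c2nn(-c3cccc(NC(=O)Nc4ccc(Cl)c(C(F)(F)F)c4)c3)cc2-c2ccncc2)c1` carries a methoxy group instead and a chloro(trifluoromethyl)phenyl urea; in this assay compound 2 gives 93%. The number of compound 2 lies within the scatter of that of compound 1, so the two cannot be told apart on these data. Both numbers point to a weak effect at the single concentration used.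

Compound 3 `COc1cc(Cl)cc(-c2nn(-c3cccc(NC(=O)Nc4ccc(Cl)c(Cl)c4)c3)cc2-c2ccncc2)c1` is reached from compound 2 by one change: chloro in place of trifluoromethyl on an aromatic carbon. Within the data shown here, no comparable step between measured compounds is available, so no size can be read off. Given that the two measured numbers sit together, the expected step from compound 2 to compound 3 is no change at the digits printed from compound 2 to compound 3 (within the scatter), that is, none beyond the scatter. Compound 3 is therefore estimated at 93%, within 82% to 100%.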

Compound 3, a percentage reported as activity, at one concentration (the size of the read-out at that concentration, not a potency): 109%
Compound 3: the middle estimate sits 16 percentage points below what was measured, outside the stated range (above it).
By their numbers in this assay, from the lowest: compounds 2 and 1 (each within the scatter of the next); then compound 3.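

On the urea aryl this aromatic carbon is not silent: in this assay chloro in place of trifluoromethyl gives a number 16 percentage points higher from compound 2 to compound 3 (beyond the scatter) and so moves the read-out toward a weaker effect at the one concentration tested. The oxygen on the chlorophenyl arm also matters, since with the 3,4-dichlorophenyl urea held fixed, methyl in place of hydrogen there gives a number 15 percentage points higher from compound 1 to compound 3 (beyond the scatter) in the same direction. Among these compounds, compound 1 and compound 2 differ in two places, so their printed values alone could not speak to either change; these two steps are the first single-change readings.

From the compounds shown here alone, whether a nitrile or an amine on this aromatic carbon would read with compound 2 or with compound 3 stays open, as does the reading at any higher concentration. Nothing at hand gives a cause for either step.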